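A few compounds are considered here, and "the series" means these few. Any claim that something is new, unique, unknown or untested is made for them only; others in the source may bear on it.

In a functional assay on DU-145 cells (Homo sapiens) for cytotoxicity, read by MTT assay (a higher number here means a weaker inhibitor, a lower number a stronger inhibitor), the two measured compounds stand as follows.
Compound 1 `CCCCCCC(C)(O)CC(=O)O[C@H](CC=C(C)C)C1=CC(=O)c2c(O)ccc(O)c2C1=O` gives > 100000 nM, which is a limit of the assay rather than a number.
Compound 2 `CC(C)=CC[C@@H](OC(=O)CC(O)c1ccccc1)C1=CC(=O)c2c(O)ccc(O)c2C1=O` gives 17000 nM.

Compound 1 therefore stands at the weak end of what is shown: its value sits at the limit of > 100000 nM in this assay, at which 1 of the 2 values shown sits, so only a limit is known for it. Among the compounds with values here, the one measured step starts from there: an at least 5.8-fold lower number from compound 1 to compound 2 (0.76 log units; beyond the scatter).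

Compound 3 `CC(C)=CC[C@@H](OC(=O)c1ccoc1)C1=CC(=O)c2c(O)ccc(O)c2C1=O` is not yet measured in this assay. It differs from compound 1 in one place: furan-3-yl in place of 2-hydroxy-2-methyloctyl on a carbonyl carbon. As in the step to compound 2, a long hydroxy-bearing chain leaves and an aromatic ring enters on the ester side of the shared core, so the measured step from compound 1 to compound 2 is the one that bears on it, and it was at least modest in the direction of a lower number.

A step of similar size and direction is expected here, namely an at least 5.0-fold lower number from compound 1 to compound 3 (0.69 log units; beyond the scatter). Compound 3 is therefore estimated at 20000 nM, with a range from 5000 nM to 100000 nM.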

Compound 3, half-maximal inhibitory concentration: > 100000 nM
Compound 3 ended at the assay's limit; the forecaster's own chance of this, stated with the estimate: 30%; middle value at least 5.0-fold (0.69 log units) from the limit.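

Placing furan-3-yl where 2-hydroxy-2-phenylethyl stood on the carbonyl carbon gives an at least 5.8-fold higher number from compound 2 to compound 3 (0.76 log units; beyond the scatter) in this assay, so an aromatic ring at this place is not enough by itself to bring a compound under the limit. Of the three compounds, only compound 2, which carries a phenyl ring and a hydroxy group on a short chain, gives a measured number, 17000 nM, so the change that counts looks narrower than simply exchanging a long chain for a ring. The step between compound 1 and compound 3 cannot be read, because both compounds stand at the same limit: the limit of > 100000 nM in this assay, at which 2 of the 3 values shown sit.

As far as these compounds go, it stays open whether the lower number of compound 2 rests on the phenyl ring, on the hydroxy group or on the two together. A phenyl ring set directly on the carbonyl carbon, a plain 2-phenylethyl chain without the hydroxy group, or a 2-amino-2-phenylethyl group with an amine in place of that hydroxy would each help to separate these parts.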